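Methyl on the indole nitrogen: a second look at lipophilicity

A few compounds are considered here, and "the series" means these few. Any claim that something is new, unique, unknown or untested is made for them only; others in the source may bear on it.

The set consists of three measured compounds and one still to be measured in a physicochemical assay for lipophilicity, read by HPLC, measured as octanol-water partition, at pH 2; a higher number here means a more lipophilic compound, a lower number a more polar compound. Compound 3 `NC(=O)C1CCN(C(=O)c2c[nH]c3ccccc23)CC1` carries a hydrogen on its aromatic nitrogen and gives 0.3. Compound 2 `Cn1cc(C(=O)N2CCC(C(N)=O)CC2)c2ccccc21` differs from it by methyl in place of hydrogen on an aromatic nitrogen and gives 1.1; the step of a number 0.80 log units higher from compound 3 to compound 2 (beyond the scatter) is beyond the scatter. Compound 1 `CN(C)C(=O)c1c[nH]c2ccccc12` gives 1.1, the same as compound 2 at the digits shown, and the difference between the cores of compound 1 and compound 3 is not broken down here.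

Compound 4 `CN(C)C(=O)c1cn(C)c2ccccc12` stands to compound 1 as compound 2 stands to compound 3: the change is methyl in place of hydrogen on an aromatic nitrogen. The two changes are the same kind of change, not the same, since in compound 1 the ring atom two ring bonds away bears a dimethylcarbamoyl group, whereas in compound 3 it bears a large group. Among the compounds shown this change occurs two times in all, and only once with a measured result.

On that single precedent, the step of a number 0.80 log units higher from compound 3 to compound 2 (beyond the scatter), an estimated step of a number 0.80 log units higher from compound 1 to compound 4 (beyond the scatter) from compound 1 to compound 4 is expected in this assay. Compound 4 is therefore expected to give about 1.9 in this assay, with a likely range from 1.5 to 2.3, resting on one measured pair only.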

Compound 4, distribution coefficient: 1.8
Compound 4: the middle estimate sits 0.10 log units above what was measured; measured number inside the range.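

In this assay, methyl in place of hydrogen on the aromatic nitrogen gives a number 0.70 log units higher from compound 1 to compound 4 (beyond the scatter), and the same kind of change on the other core gave a number 0.80 log units higher from compound 3 to compound 2 (beyond the scatter), so both measured pairs move upward and both steps lie beyond the scatter. This shows that the step carried over in direction from the core of compound 3 to the core of compound 1, even though the ring atom two ring bonds away bears a dimethylcarbamoyl group in compound 1 and a larger group in compound 3, but two pairs are too few to set a rule for the series or to predict the step on a core not shown here. Nothing given here accounts for the step on either core, and no measurement bears on what lies behind it.

The compounds shown leave open whether an ethyl group or a longer chain on the aromatic nitrogen would continue the upward move seen with methyl. They also leave open whether the step would hold with an amine or a carboxylic acid in place of the dimethylcarbamoyl group, or in any measurement other than this assay.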